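The source may report more compounds than this note shows. Statements on the series, on what has been measured and on what is new or still open speak of the compounds shown alone.

Of the compounds shown here, two that share one core have been tested for their ability to slow the growth of a human brain tumour cell line, in a functional assay on SF-268 cells (Homo sapiens) for antiproliferative activity, read by MTT assay, with a stated time of 96 h; on this read-out higher numbers stand for weaker inhibition and lower numbers for stronger inhibition. Compound 1 `O=C1C2=C(C(=O)c3ncccc31)C1(CS2)NC(=O)N(c2ccc([N+](=O)[O-])cc2)C1=O` gives 1520 nM, the lower of the two numbers and therefore the stronger inhibitor. Compound 2 `O=C1NN(c2ccc([N+](=O)[O-])cc2)C(=O)C2(CSC3=C2C(=O)c2ncccc2C3=O)N1` gives 3550 nM, a weaker result that lies beyond the usual scatter. Compound 3 `CC(C)(C)c1ccc(N2C(=O)NC3(CSC4=C3C(=O)c3ncccc3C4=O)C2=O)cc1` has not yet been measured; it differs from compound 1 in one place: tert-butyl in place of nitro on an aromatic carbon. Going by the values given here, no measured pair shows this change, so its effect is unknown. Compound 3 is expected at an estimated 2000 nM, plausibly between 700 nM and 6000 nM. The expected step of a 1.3-fold higher number from compound 1 to compound 3 (0.12 log units; within the scatter) is small, within the scatter.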

Compound 3, half-maximal inhibitory concentration: 500 nM
For compound 3 the middle estimate is 4.0-fold (0.60 log units) above the measured one, and the stated range ends above it.
By their numbers in this assay, from the lowest: compound 3; then compound 1; then compound 2.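

Replacing nitro with tert-butyl on the aromatic ring brings a 3.0-fold lower number from compound 1 to compound 3 (0.48 log units; beyond the scatter) and so stronger inhibition. This position therefore does not depend on the nitro group: a group of carbon only, with no hydrogen-bond acceptors, is accepted here and gives the better result. Nothing measured here explains the gain.

On these data alone, whether a methyl group, an amine or a carboxylic acid at this place would do better or worse remains open. So does whether tert-butyl brings a similar gain on the core of compound 2.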